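Benzylamino to diethylamino on the core of compound 2

The compounds below may be only part of what the source reports. "The series", "measured", "known", "first", "only" and "open" are said of these compounds alone.

Compound 1 `N#Cc1c(Nc2ccccc2)c(Cl)c2nc(N)nc(N)c2c1F` gives 47 ug/mL
Compound 2 `N#Cc1c(NCc2ccccc2)c(Cl)c2nc(N)nc(N)c2c1F` gives 0.3 ug/mL
Compound 3 `N#Cc1c(NCc2ccccc2)c(F)c2nc(N)nc(N)c2c1F` gives 14 ug/mL

In a functional assay on HL-60 cells (Homo sapiens) for cytotoxicity, read by MTT assay (on this read-out higher numbers stand for weaker inhibition and lower numbers for stronger inhibition), compound 2 has the lowest number of the three, and both its gaps to the others lie beyond the scatter. Compound 4 `CCN(CC)c1c(C#N)c(F)c2c(N)nc(N)nc2c1Cl` differs from it in one group: diethylamino in place of benzylamino on an aromatic carbon. Among the measured compounds shown here, two measured steps bear on this. Benzyl in place of phenyl on a nitrogen gave a 160-fold lower number from compound 1 to compound 2 (2.19 log units; beyond the scatter), and fluoro in place of chloro gave a 47-fold higher number from compound 2 to compound 3 (1.67 log units; beyond the scatter). For the measured compounds named here, both were large, yet no measured compound carries diethylamino. Since compound 2 lost much of its standing after a single small change in a 47-fold higher number from compound 2 to compound 3 (1.67 log units; beyond the scatter), a large rise is expected, estimated as a 17-fold higher number from compound 2 to compound 4 (1.22 log units; beyond the scatter) in this assay. For compound 4 the expected value is 5 ug/mL, with an estimated range of 0.8 ug/mL to 30 ug/mL.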

Compound 4, half-maximal inhibitory concentration: 2.3 ug/mL
Beside the measured number, compound 4's estimate is 2.2-fold (0.34 log units) above it, and the stated range covers the measured number.
By their numbers in this assay, from the lowest: compound 2; then compound 4; then compound 3; then compound 1.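

In this assay, the aromatic carbon ortho to a chloro group and ortho to a cyano group still gives a low number with diethylamino, which has no ring and no hydrogen-bond donor, though replacing benzylamino costs a 7.7-fold higher number from compound 2 to compound 4 (0.88 log units; beyond the scatter). Diethylamino in place of anilino gives a 20-fold lower number from compound 1 to compound 4 (1.31 log units; beyond the scatter), so a ring on this amine is not needed to improve on anilino. Nothing available here explains either step.

Going by these compounds, whether dimethylamino or morpholine on this carbon would match benzylamino remains open. Also open, on these data alone, is whether fluoro in place of chloro would raise the number with diethylamino as it does with benzylamino.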